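The source may hold more compounds than are shown below. What is called first, only, known or untested is meant among the compounds shown, and "the series" means these compounds.

So far, two compounds that share a core have been tested in a functional assay on HT-29 cells (Homo sapiens) for antiproliferative activity, read by sulforhodamine B assay, with a stated time of 72 h; a lower number here means a stronger inhibitor, a higher number a weaker inhibitor. Here, compound 1 `FC(F)(F)c1ccccc1NC(=S)N/N=C/c1ccc2ccccc2n1` gives 18100 nM and compound 2 `N#Cc1ccc(NC(=S)N/N=C/c2ccc3ccccc3n2)cc1` gives 15600 nM. These two numbers lie within the usual scatter of each other, so the data do not separate compound 2 from compound 1.

Compound 3 `Cc1ccc(NC(=S)N/N=C/c2ccc3ccccc3n2)cc1` differs from compound 2 in one place, going from 4-cyanophenyl to 4-methylphenyl: methyl in place of cyano on an aromatic carbon. This puts methyl in place of cyano on an aromatic carbon, para to a large group. Among the compounds with values here, no measured pair shows this change on its own, so the forecast is loose. Starting from compound 2 at 15600 nM, no step beyond the scatter is expected, and the estimated step is a 1.1-fold lower number from compound 2 to compound 3 (0.05 log units; within the scatter). The estimated value for compound 3 is 14000 nM, with an expected range from 4500 nM to 40000 nM.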

Compound 3, half-maximal inhibitory concentration: 85500 nM
For compound 3 the middle estimate is 6.1-fold (0.79 log units) below the measured one; measured number above the stated range.
By their numbers in this assay, from the lowest: compounds 2 and 1 (each within the scatter of the next); then compound 3.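

The ring position para to a large group is now shown to affect the result: methyl in place of cyano on this aromatic carbon gives a 5.5-fold higher number from compound 2 to compound 3 (0.74 log units; beyond the scatter) in this assay. Compounds 1 and 2 could not show this, since they differ in more than one place and their values lie within the scatter of each other. Here, a change of a single group on the ring moves the number beyond the scatter, although nothing available explains this shift.

This single pair cannot show how other groups would behave at the same position. An amine, a methoxy group or a carboxylic acid there might bring the number close to that of compound 2, close to that of compound 3, or to somewhere else entirely.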